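Cyclopropylamino replaces dimethylamino on a quinazoline-type core

The source may hold more compounds than are shown below. What is called first, only, known or untested is meant among the compounds shown, and "the series" means these compounds.

Measured compounds:
compound 1, `CCCNc1nc(NCc2ccc(C(=O)Nc3ccc(F)cc3)cc2)c2ccccc2n1`, 1600 nM
compound 2, `CC1CN(c2nc(NCc3ccc(C(=O)Nc4ccc(F)cc4)cc3)c3ccccc3n2)CCN1`, 3200 nM
compound 3, `CN(C)c1nc(NCc2ccc(C(=O)Nc3ccc(F)cc3)cc2)c2ccccc2n1`, 2600 nM

In a functional assay on SW480 cells (Homo sapiens) for inhibition, read by luminescence and resazurin assay, with a stated time of 3 days (on this read-out higher numbers stand for weaker inhibition and lower numbers for stronger inhibition), compound 3 gives 2600 nM, the second highest of the three numbers. Its nearest neighbour is compound 2, where a 1.2-fold lower number from compound 2 to compound 3 (0.09 log units; within the scatter). The furthest is compound 1, where a 1.6-fold higher number from compound 1 to compound 3 (0.21 log units; within the scatter); and a 2.0-fold higher number from compound 1 to compound 2 (0.30 log units; within the scatter). Every step among the three measured compounds therefore lies within the scatter, and none of them can be ordered against the others.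

Compound 4, `O=C(Nc1ccc(F)cc1)c1ccc(CNc2nc(NC3CC3)nc3ccccc23)cc1`, has not yet been measured. It differs from compound 3 in one place: cyclopropylamino in place of dimethylamino on an aromatic carbon. Among the compounds with values here, of the measured steps, the one from compound 1 to compound 3 bears most directly on this change, since compound 1 also carries an amino group with a hydrogen-bond donor on that aromatic carbon, and that step was small. Compound 4 is accordingly expected to land close to compound 1 and compound 3 alike, with a step of a 1.4-fold lower number from compound 3 to compound 4 (0.16 log units; within the scatter) that is itself within the scatter. Compound 4 is estimated at 1800 nM, with a likely range from 800 nM to 4000 nM.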

Compound 4, half-maximal inhibitory concentration: 2600 nM
Compound 4: the middle estimate sits 1.4-fold (0.16 log units) below what was measured; the range from low to high includes it.
By their numbers in this assay, from the lowest: compounds 1, 3, 4 and 2 (each within the scatter of the next).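

In this assay, cyclopropylamino in place of dimethylamino on the aromatic carbon between two ring nitrogen atoms gives no change at the digits printed from compound 3 to compound 4 (within the scatter), so bringing in a three-membered ring and a hydrogen-bond donor together leaves no readable mark at this position. The other two steps agree: closing the chain, with cyclopropyl in place of propyl on the same nitrogen, gives a 1.6-fold higher number from compound 1 to compound 4 (0.21 log units; within the scatter), and cyclopropylamino in place of 3-methylpiperazin-1-yl gives a 1.2-fold lower number from compound 2 to compound 4 (0.09 log units; within the scatter), which means that all four groups, open-chain or ring, with or without that donor, now cannot be told apart in this assay. Nothing available explains this flat picture.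

As far as these compounds go, whether a carboxylic acid, an anilino group or a longer chain ending in an amine on this carbon would produce a step beyond the scatter remains open. From the compounds shown here alone, all four compounds also share everything else in their structures, so it is equally open whether this position would stay as flat if the fluorophenyl amide were replaced.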